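A methoxy in place of a methyl

The source may hold more compounds than are shown below. What is called first, only, known or untested is meant among the compounds shown, and "the series" means these compounds.

In a functional assay on A549 cells (Homo sapiens) for cytotoxicity, with a stated time of 48 h (a lower number here means a stronger inhibitor, a higher number a weaker inhibitor), compound 1 (`Cc1ccc2c(=O)cc(/C=C/[S+](C)[O-])oc2c1`) gives 2000 nM in a set with two others: compound 2 (`CC(C)COc1ccc2oc(/C=C/[S+](C)[O-])cc(=O)c2c1`) gives 1100 nM and compound 3 (`Cc1cccc2c(=O)cc(/C=C/[S+](C)[O-])oc12`) gives 1700 nM on the same read-out. Compound 1 therefore stands level with both, since all three numbers lie within the scatter of one another. Compound 4 (`COc1ccc2c(=O)cc(/C=C/[S+](C)[O-])oc2c1`) has not yet been measured. It carries methoxy in place of methyl on an aromatic carbon of compound 1 (methoxy in place of methyl on an aromatic carbon) and otherwise keeps the same structure. Within the data shown here, no measured pair shows this change, so the expectation rests on compound 1 at 2000 nM and is for no step beyond the scatter in this assay in either direction. The expected step of a 1.2-fold lower number from compound 1 to compound 4 (0.07 log units; within the scatter) stays within the scatter. Compound 4 is expected at 1700 nM with an estimated range from 800 nM to 3500 nM once measured.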

Compound 4, half-maximal inhibitory concentration: 2200 nM
Estimate against measurement, compound 4: 1.3-fold (0.11 log units) below; the measured number falls inside the stated range.
By their numbers in this assay, from the lowest: compounds 2, 3, 1 and 4 (each within the scatter of the next).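

Among these compounds, the step of a 1.1-fold higher number from compound 1 to compound 4 (0.04 log units; within the scatter) in this assay gives the first direct comparison in this set, as the earlier compounds offered no pair differing in one place. At this aromatic carbon, methoxy in place of methyl, with one more heavy atom and one hydrogen-bond acceptor, leaves the number within the scatter. No measurement bears on why this step is so small. As far as these compounds go, whether an amine or a carboxylic acid on this carbon would move the number beyond the scatter remains open, as does the effect of a longer chain there.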